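The source may report more compounds than this note shows. Statements on the series, on what has been measured and on what is new or still open speak of the compounds shown alone.

Compound 1 `COc1cc2c(Oc3ccc(NC(=O)c4nn(-c5ccc(C)cc5C)cc(C)c4=O)cc3)ccnc2cc1OCCCCCCC(=O)NO` gives 440 nM in a functional assay on HCT-116 cells (Homo sapiens) for inhibition, read by MTT assay, with a stated time of 72 h; a lower number here means a stronger inhibitor, a higher number a weaker inhibitor. Compound 2 `COc1cc2c(Oc3ccc(NC(=O)c4nn(-c5ccccc5F)cc(C)c4=O)cc3F)ccnc2cc1OCCCCCC(=O)NO` gives 590 nM in this assay; the two numbers lie within the scatter of each other, so compound 1 has the lower of the two numbers without standing apart from compound 2. Compound 2 differs from compound 1 in more than one place, so the pair says nothing about any single change. Compound 3 `COc1cc2c(Oc3ccc(NC(=O)c4nn(-c5ccc(C)cc5)cc(C)c4=O)cc3)ccnc2cc1OCCCCCCC(=O)NO` has not been measured. It differs from compound 1 by hydrogen in place of methyl on an aromatic carbon, the 2,4-dimethylphenyl of compound 1 becoming 4-methylphenyl. Among the measured compounds shown here, no measured pair isolates this change, so the size of the step rests on expectation alone. Starting from compound 1 at 440 nM, the step of a 1.1-fold higher number from compound 1 to compound 3 (0.06 log units; within the scatter) is expected to be small, most likely not beyond the scatter, with no direction favoured. Compound 3 is therefore estimated at 500 nM in this assay, within a range of 200 nM to 1300 nM.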

Compound 3, half-maximal inhibitory concentration: 400 nM
Compound 3: the middle estimate sits 1.3-fold (0.10 log units) above what was measured; low and high end bracket the measured number.
By their numbers in this assay, from the lowest: compounds 3, 1 and 2 (each within the scatter of the next).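

In this assay, the series now has its first pair that differs in one place: a 1.1-fold lower number from compound 1 to compound 3 (0.04 log units; within the scatter). Hydrogen in place of methyl on this aromatic carbon, ortho to a large group, leaves the number within the scatter, so in this pair the 4-methylphenyl of compound 3 serves as well as the 2,4-dimethylphenyl of compound 1. No evidence on the cause of this result is available.

Open, from the compounds shown here alone, is how this carbon responds to a group other than methyl or hydrogen, such as an amine, a carboxylic acid or a chlorine atom. Also open, going by these compounds, is whether the same step would stay within the scatter on the background of compound 2, which differs from compound 1 in more than one place.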